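Same place, smaller group: predicting compound 4's stability

The source may report more compounds than this note shows. Statements on the series, on what has been measured and on what is new or still open speak of the compounds shown alone.

Measured in an ADME assay on microsomes from liver (Mus musculus) for metabolic stability, read by LC-MS, with a stated time of 10 min, tested at 0.5 uM; on this read-out higher numbers stand for a more stable compound and lower numbers for a less stable compound:
- compound 1 `c1cnc2c(c1)CCC[C@@H]2N(CCCN1CCNCC1)Cc1cc2ccccc2cn1`: 74%
- compound 2 `c1cnc2c(c1)CN[C@H](CN(CCCN1CCNCC1)[C@H]1CCCc3cccnc31)C2`: 63%
- compound 3 `c1cnc2c(c1)CN[C@@H](CN(CCCN1CCNCC1)[C@H]1CCCc3cccnc31)C2`: 78%

Compound 3 shares the top of this small set. The data show a number 4 percentage points higher from compound 1 to compound 3 (within the scatter), and also a number 15 percentage points higher from compound 2 to compound 3 (beyond the scatter). That second, larger step goes with the fact that compounds 2 and 3 differ only in the configuration as drawn.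

Compound 4 `c1cnc(CN(CCCN2CCNCC2)[C@H]2CCCc3cccnc32)nc1` has not yet been measured. Its structure departs from that of compound 3 by one exchange: a group of 6 heavy atoms (4 carbon, 2 nitrogen; one six-membered aromatic ring with 2 hetero atoms) in place of a group of 10 heavy atoms (8 carbon, 2 nitrogen; one six-membered non-aromatic ring with 1 hetero atom, one six-membered aromatic ring with 1 hetero atom), on a saturated chain carbon bound to an amine nitrogen. The entering group is pyrimidin-2-yl, a single ring and smaller than the group it replaces.

The closest guides are the earlier exchanges at this same place, which gave a number 11 percentage points lower from compound 1 to compound 2 (beyond the scatter) and a number 4 percentage points higher from compound 1 to compound 3 (within the scatter). One was modest and the other stayed within the scatter, and neither involved a group as small as this one. No clear direction follows from them, so no change beyond the scatter is expected, although the uncertainty is wide. The estimated step in this assay is a number 4 percentage points lower from compound 3 to compound 4 (within the scatter). For compound 4 the expected value is 74%, with an estimated range of 57% to 90%.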

Compound 4, percent of the compound remaining: 78%
For compound 4 the middle estimate is 4 percentage points below the measured one; the range from low to high includes it.
By their numbers in this assay, from the lowest: compound 2; then compounds 1, 3 and 4 (each within the scatter of the next).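

In this assay, the smaller, single-ring pyrimidin-2-yl does as well on a saturated chain carbon bound to an amine nitrogen as the larger groups do, with no change at the digits printed from compound 3 to compound 4 (within the scatter) and a number 4 percentage points higher from compound 1 to compound 4 (within the scatter). Two fused rings are therefore not required at this place for this read-out, and only compound 2 stands apart, with a number 15 percentage points higher from compound 2 to compound 4 (beyond the scatter). The low number of compound 2 does not simply follow group size, since compound 3 carries the same larger group, and the contrast between them comes down to this: the fact that compounds 2 and 3 differ only in the configuration as drawn

From the compounds shown here alone, whether a plain phenyl ring, with no ring nitrogen, or a much smaller group such as methyl would give a similar number at this place remains open. The compounds shown also leave open whether the shared core would tolerate other changes in the same way.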